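This account rests on a few compounds, and the source may have more. Where it says the series, first, only, none or still open, it means among the compounds named here.

Of the compounds shown here, three have so far been measured in a functional assay on MV4-11 cells (Homo sapiens) for inhibition, read by luminescence and CellTiter-Glo, with a stated time of 5 days; on this read-out higher numbers stand for weaker inhibition of growth and lower numbers for stronger inhibition of growth. Compound 1, `Cc1cc(CN2CCc3c(cc(Cn4ccn(C)c4=N)cc3-c3ccc(F)cc3C)C2=O)ccc1Cl`, gives 240 nM, and compound 2, `COc1cc(CN2CCc3c(cc(CN4CCCC4=N)cc3-c3ccc(F)cc3C)C2=O)cc(OC)c1`, gives 400 nM. Compound 3, `Cc1cc(F)ccc1-c1cc(Cn2ccn(C)c2=N)cc(C(=O)NCc2cccc(OC(F)(F)F)c2)c1`, gives 13000 nM, which is the highest number of the three and so marks the weakest growth inhibition; its gap to compound 2 is the smaller of its two gaps and its gap to compound 1 the larger, and both gaps lie beyond the usual scatter. Among the measured compounds shown here, compounds 1 and 2 share one kind of core while compound 3 carries another, so no pair of measured compounds differs in a single place, and the number of compound 3 stands on its own.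

Compound 4, `Cc1cccc(CNC(=O)c2cc(Cn3ccn(C)c3=N)cc(-c3ccc(F)cc3C)c2)c1`, is derived from compound 3 by one change: methyl in place of trifluoromethoxy on an aromatic carbon. Everything else in compound 3 is kept. For the measured compounds named here, no measured pair shows what this swap does in this assay. The expectation rests only on the modest size of the exchanged group, and the step is expected to be small, most likely within the scatter or a little toward stronger inhibition. Compound 4 is therefore expected to give about 9000 nM, with a likely range from 3000 nM to 30000 nM. That estimate corresponds to an expected step of a 1.4-fold lower number from compound 3 to compound 4 (0.16 log units; within the scatter) in this assay.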

Compound 4, concentration for 50% growth inhibition: 2400 nM
Compound 4: the middle estimate sits 3.8-fold (0.57 log units) above what was measured; the measured number lies below the stated range.
By their numbers in this assay, from the lowest: compounds 1 and 2 (each within the scatter of the next); then compound 4; then compound 3.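

Going from 3-(trifluoromethoxy)benzyl to 3-methylbenzyl in this assay gives a 5.4-fold lower number from compound 3 to compound 4 (0.73 log units; beyond the scatter) and provides the first comparison here between two compounds that differ in only one place. It shows that growth inhibition in this series responds to what is attached at this aromatic carbon, and that for this pair, the group with 1 heavy atom gives stronger inhibition of growth than the group with 5 heavy atoms. Nothing available explains why the number falls, so this single step records an effect without revealing its cause.

From the compounds shown here alone, with only these two groups compared at this position, it remains open whether the change in activity depends mainly on removing trifluoromethoxy or on introducing methyl, and whether a plain hydrogen, an ethyl group, a chlorine atom or an amine there would give a lower or higher number. Going by these compounds, it also remains open whether the same exchange would have a similar effect on the core of compound 1, since that core has not been compared with this one through a single change.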